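This account rests on a few compounds, and the source may have more. Where it says the series, first, only, none or still open, it means among the compounds named here.

Compound 1 `CC1CCN(C2CCN(S(=O)(=O)c3cccnc3F)CC2)CC1` carries a 2-fluoropyridin-3-yl group on its sulfonyl sulfur. In a functional assay on DLD-1 cells (Homo sapiens) for antiproliferative activity, read by CellTiter-Glo, with a stated time of 72 h (a lower number here means a stronger inhibitor, a higher number a weaker inhibitor), compound 1 gives only a limit, > 5000 nM, so no number is known for it. Among the three measured compounds, compound 1 sits at the limit of > 5000 nM in this assay, at which 1 of the 3 values shown sits, the weak end of what has been seen. Two comparison points are available. Compound 2 `Cc1cc(C)c(S(=O)(=O)N2CCC(N3CCCCCC3)CC2)c(C)c1`, an aryl sulfonamide on a different amine, gives 5.3 nM in this assay. Compound 3 `CC1CCN(C2CCN(C(=O)c3ccc(OC(F)(F)F)cc3)CC2)CC1` keeps the same amine as compound 1 but carries a benzoyl group with a trifluoromethoxy substituent in place of the sulfonyl, and in this assay compound 3 gives 426 nM.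

Compound 4 `CC1CCN(C2CCN(S(=O)(=O)c3cc(Cl)cc(Cl)c3)CC2)CC1` has not yet been measured. It differs from compound 1 as follows: 3,5-dichlorophenyl in place of 2-fluoropyridin-3-yl on a sulfonyl sulfur. Because compound 1 sits at the limit of > 5000 nM in this assay, at which 1 of the 3 values shown sits, while the other aryl sulfonamide, compound 2, reaches 5.3 nM, a large step toward stronger inhibition is expected here, well beyond the usual scatter. The step from compound 1 to compound 4 in this assay is estimated as an at least 83-fold lower number from compound 1 to compound 4 (1.92 log units; beyond the scatter). For compound 4 the expected value in this assay is 60 nM, with a plausible range from 10 nM to 500 nM.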

Compound 4, half-maximal inhibitory concentration: 3400 nM
Beside the measured number, compound 4's estimate is 57-fold (1.75 log units) below it; measured number outside the range, above it.
By their numbers in this assay, from the lowest: compound 2; then compound 3; then compound 4. At a limit, above all of these: compound 1.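

With 3,5-dichlorophenyl on the sulfonyl sulfur, the core of compound 1 yields a measurable read-out: in this assay compound 4 gives 3400 nM, a number rather than a limit, so an aryl change at this place alone can bring the series into the range the assay can count. Compound 1 gives only a limit, > 5000 nM, and no number. As far as these compounds go, the exchange of 2-fluoropyridin-3-yl for 3,5-dichlorophenyl can therefore be read only as an at least 1.4-fold lower number from compound 1 to compound 4 (0.16 log units; that floor lies within the scatter), and its true size stays unknown because one end of the step is a limit: the limit of > 5000 nM in this assay, at which 1 of the 4 values shown sits.

The compounds shown leave open whether the two chlorines or the change from a pyridine ring to a ring of carbon only accounts for the measurable value of compound 4, as this single exchange alters both at once. From the compounds shown here alone, how an unsubstituted phenyl, a 3-chlorophenyl or a chloropyridine would read on the same sulfonyl sulfur also remains open, and any of these could help separate the two parts of the change.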